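This account rests on a few compounds, and the source may have more. Where it says the series, first, only, none or still open, it means among the compounds named here.

Among the measured compounds shown here, in a functional assay for inhibition, with Rattus norvegicus as the target (a lower number here means a stronger inhibitor, a higher number a weaker inhibitor), compound 2 (`CC(C)(C)CCN/C(=C\[N+](=O)[O-])Nc1cccnc1`) gives 2000 nM, the only single figure so far. Compound 1 (`C[C@@H](N/C(=C\[N+](=O)[O-])Nc1cccnc1)C(C)(C)C`) gives 10 nM; 1000 nM (2 entries), and these two entries fix no single position for it. Compound 3 (`CC(C)N/C(=C\[N+](=O)[O-])Nc1cccnc1`) carries isopropyl in place of 3,3-dimethylbutyl on an amine nitrogen. For the measured compounds named here, no measured step covers this change. A modest weakening in this assay is expected, though a result within the scatter of compound 2 would not surprise. The expected size is a 2.5-fold higher number from compound 2 to compound 3 (0.40 log units; beyond the scatter). For compound 3 the estimate is 5000 nM, with an expected range of 1200 nM to 20000 nM.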

Compound 3, half-maximal inhibitory concentration: 31600 nM
Compound 3: the middle estimate sits 6.3-fold (0.80 log units) below what was measured; the whole stated range lies below it.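

Replacing 3,3-dimethylbutyl with isopropyl on an amine nitrogen weakens inhibition markedly in this assay, with a 16-fold higher number from compound 2 to compound 3 (1.20 log units; beyond the scatter). Among the compounds shown here, this is the first measured step, and it shows that this nitrogen substituent is not a neutral place for change. The smaller group, with 3 heavy atoms against 6, is clearly the weaker of this pair.

On these data alone, whether a straight butyl chain or a cyclohexyl ring on this nitrogen would fall between these two values remains open. Compound 1 gives no single reference point: the several entries of compound 1 in this assay, 10 nM; 1000 nM (2 entries)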